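This account rests on a few compounds, and the source may have more. Where it says the series, first, only, none or still open, it means among the compounds named here.

The measured compounds:
compound 1, `Nc1ccccc1NC(=O)c1ccc(CNc2nc(Cl)nc3c2ncn3Cc2ccccc2)cc1`, 7.7%
compound 2, `Nc1ccccc1NC(=O)c1ccc(Cn2cnc3c(NCc4ccccc4)nc(Cl)nc32)cc1`, 68.3%
compound 3, `Nc1ccccc1NC(=O)c1ccc(COCNc2nc(Nc3ccccc3)c3ncn(C4CCCC4)c3n2)cc1`, 75.2%

In a functional assay on HCT-116 cells (Homo sapiens) for antiproliferative activity, read by CCK-8 assay, with a stated time of 72 h, tested at 2 uM (on this read-out higher numbers stand for a stronger effect at the one concentration tested and lower numbers for a weaker effect), compound 1 gives 7.7%, the lowest of the three numbers. Compound 2 gives 68.3% and compound 3 gives 75.2%, both well above compound 1 and beyond the scatter of repeated measurements. Compound 4, `Nc1ccccc1NC(=O)c1ccc(CNc2nc(Cl)nc3c2ncn3C2CCCC2)cc1`, has not yet been measured in this assay. It differs from compound 1 in a single place: cyclopentyl in place of benzyl on an aromatic nitrogen. Going by the values given here, no measured pair shows this change by itself, so its effect cannot be read off directly. Compound 3 does carry a cyclopentyl on an aromatic nitrogen and gives 75.2%, but it differs from compound 1 in several further places, so its number is only a loose hint. An upward step from compound 1 is expected, of the size a number 17.3 percentage points higher from compound 1 to compound 4 (beyond the scatter), beyond the scatter but with wide uncertainty. Compound 4 is estimated to give 25%, within a range from 5% to 55%.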

Compound 4, a percentage reported as inhibition, at one concentration (the size of the read-out at that concentration, not a potency): 75.6%
Compound 4: the middle estimate sits 50.6 percentage points below what was measured; measured number outside the range, above it.
By their numbers in this assay, from the lowest: compound 1; then compounds 2, 3 and 4 (each within the scatter of the next).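

In this assay, going by these compounds alone, cyclopentyl in place of benzyl on an aromatic nitrogen brings a number 67.9 percentage points higher from compound 1 to compound 4 (beyond the scatter), so this position alone can carry a large change in the read-out, which no earlier pair could show. The change swaps a six-membered aromatic ring for a five-membered non-aromatic ring and removes heavy atoms, while hydrogen-bond donor and acceptor counts stay the same in both groups. Nothing given here accounts for the size of this step.

The compounds shown leave open how cyclopropyl, a smaller ring, an isopropyl group, or a piperidine ring, which carries an amine, would behave on this nitrogen. They also leave open whether the step would recur on a different core, and how it would look as a potency rather than at one concentration.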